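The compounds below may be only part of what the source reports. "The series", "measured", "known", "first", "only" and "open" are said of these compounds alone.

Of the compounds shown here, three sharing one core have been tested in a functional assay on Lu cells (Homo sapiens) for antiproliferative activity; on this read-out higher numbers stand for weaker inhibition and lower numbers for stronger inhibition. Compound 1 `COc1ccc(/C=C/C(=O)c2ccc(OCCn3cc(CN4C(=O)/C=C/C(C)(C)C/C=C(\C)CC/C=C/4C)nn3)cc2O)cc1` gives 1.67 ug/mL. Compound 2 `COc1ccccc1/C=C/C(=O)c1ccc(OCCn2cc(CN3C(=O)/C=C/C(C)(C)C/C=C(\C)CC/C=C/3C)nn2)cc1O` gives 2.4 ug/mL, the highest of the three numbers, and compound 3 `C/C1=C\CC(C)(C)/C=C/C(=O)N(Cc2cn(CCOc3ccc(C(=O)/C=C/c4ccc(C)cc4)c(O)c3)nn2)/C(C)=C/CC1` gives 0.91 ug/mL. Compound 2 sits closest to compound 1, with a 1.4-fold higher number from compound 1 to compound 2 (0.16 log units; within the scatter), and furthest from compound 3, with a 2.6-fold lower number from compound 2 to compound 3 (0.42 log units; beyond the scatter); between compound 1 and compound 3 the step is a 1.8-fold lower number from compound 1 to compound 3 (0.26 log units; within the scatter).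

Compound 4 `C/C1=C\CC(C)(C)/C=C/C(=O)N(Cc2cn(CCOc3ccc(C(=O)/C=C/c4ccc(C(C)C)cc4)c(O)c3)nn2)/C(C)=C/CC1` differs from compound 2 in one place: 4-isopropylphenyl in place of 2-methoxyphenyl on a double-bonded chain carbon bound to a double-bonded chain carbon. The step from compound 2 to compound 3 bears most directly on this change, since it also replaces the 2-methoxyphenyl with a group carrying a carbon substituent on the ring, and it gave a modest step beyond the scatter toward stronger inhibition. The step from compound 1 to compound 3 points the same way but stays within the scatter. A 4-isopropylphenyl has not been tested here, so its effect beyond that of 4-methylphenyl cannot be read from these compounds.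

On that basis a step of about a 2.4-fold lower number from compound 2 to compound 4 (0.38 log units; beyond the scatter) toward stronger inhibition is expected, and compound 4 is estimated to give 1 ug/mL in this assay, within a range of 0.4 ug/mL to 2.5 ug/mL.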

Compound 4, half-maximal inhibitory concentration: 0.77 ug/mL
Estimate against measurement, compound 4: 1.3-fold (0.11 log units) above; low and high end bracket the measured number.
By their numbers in this assay, from the lowest: compounds 4, 3, 1 and 2 (each within the scatter of the next, the first and the last beyond it).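

In this assay, a second group with a carbon substituent on the ring now stands on the double-bonded chain carbon, and 4-isopropylphenyl in place of 2-methoxyphenyl gives a 3.1-fold lower number from compound 2 to compound 4 (0.49 log units; beyond the scatter), so the step seen with 4-methylphenyl is not a single case. Measured against the 4-methoxyphenyl of compound 1, the isopropyl group also clears the scatter, with a 2.2-fold lower number from compound 1 to compound 4 (0.34 log units; beyond the scatter), which the methyl group of compound 3 did not do. Even so, isopropyl in place of methyl on the aromatic carbon gives only a 1.2-fold lower number from compound 3 to compound 4 (0.07 log units; within the scatter), so compound 3 and compound 4 cannot be told apart and the added carbons bring no readable gain.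

Nothing shown here accounts for why these numbers differ. Also open, from the compounds shown here alone, is whether the gain follows from the carbon substituent itself or from where it sits on the ring, since compound 2 differs from compound 3 and compound 4 in both, and how a 4-tert-butylphenyl, a 4-aminophenyl or a 4-carboxyphenyl would behave in this assay.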